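A pentyl chain replaces 2-(3-methoxyphenyl)ethenyl

The source may report more compounds than this note shows. Statements on the series, on what has been measured and on what is new or still open speak of the compounds shown alone.

Compound 1 `C=C1C(=O)O[C@H]2CC3=C[C@H](C/C(C)=C/[C@@H](OC(=O)c4ccc([N+](=O)[O-])cc4)[C@H]12)OC3=O`: > 10000 nM
Compound 2 `C=C1C(=O)O[C@H]2CC3=C[C@H](C/C(C)=C/[C@@H](OC(=O)/C=C/c4ccc(N(C)C)cc4)[C@H]12)OC3=O`: 1300 nM
Compound 3 `C=C1C(=O)O[C@H]2CC3=C[C@H](C/C(C)=C/[C@@H](OC(=O)/C=C/c4cccc(OC)c4)[C@H]12)OC3=O`: > 10000 nM

In a functional assay on NCI-H460 cells (Homo sapiens) for cytotoxicity, read by MTT assay, with a stated time of 48 h (a lower number here means a stronger inhibitor, a higher number a weaker inhibitor), compound 3 gives > 10000 nM, which is a limit and not a number. Compound 1 likewise gives only a limit, > 10000 nM. Together they make up (the limit of > 10000 nM in this assay, at which 2 of the 3 values shown sit). Compound 2 alone gives a true reading, 1300 nM.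

Compound 4 `C=C1C(=O)O[C@H]2CC3=C[C@H](C/C(C)=C/[C@@H](OC(=O)CCCCC)[C@H]12)OC3=O` carries pentyl in place of 2-(3-methoxyphenyl)ethenyl on a carbonyl carbon. Changes on this same carbonyl carbon have already moved the number. The first measured step is an at least 7.6-fold lower number from compound 1 to compound 2 (0.88 log units; beyond the scatter), and the second is an at least 7.6-fold higher number from compound 2 to compound 3 (0.88 log units; beyond the scatter). Both lie beyond the scatter, while a step that the two limits leave unreadable from compound 1 to compound 3 cannot be sized. For the measured compounds named here, no measured compound has a ring-free chain at this place, so these steps bound the possible size without giving the direction. Going by the values given here, compound 2, at 1300 nM, is the only compound of this series with a true reading in this assay, so only a small move towards a lower number is expected, and it may not be readable. The expected change is an at least 1.4-fold lower number from compound 3 to compound 4 (0.15 log units; that floor lies within the scatter). For compound 4 the estimated value is 7000 nM, with an expected range of 2000 nM to 20000 nM.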

Compound 4, half-maximal inhibitory concentration: 5900 nM
For compound 4 the middle estimate is 1.2-fold (0.07 log units) above the measured one, and the stated range covers the measured number.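

Compound 4, with pentyl on the carbonyl carbon, is the second compound of the series to give a true reading in this assay, so an aromatic ring at this place is not required for a reading inside the range of the assay. For the compounds shown here, the only comparison that can be sized fully is a 4.5-fold higher number from compound 2 to compound 4 (0.66 log units; beyond the scatter) and shows that pentyl does not match the 2-(4-(dimethylamino)phenyl)ethenyl group here. The two other steps, an at least 1.6-fold lower number from compound 3 to compound 4 (0.22 log units; that floor lies within the scatter) and an at least 1.6-fold lower number from compound 1 to compound 4 (0.22 log units; that floor lies within the scatter) are floors that lie within the scatter, because compound 1 and compound 3 each stand at a limit: the limit of > 10000 nM in this assay, at which 2 of the 4 values shown sit.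

Pentyl is the only ring-free chain shown, so it remains open whether a shorter chain such as ethyl or a longer chain such as octyl would move the number, and in which direction. On these data alone, it also remains open how much of the lower number of compound 2 depends on its dimethylamino group, a question that a primary amine or a carboxylic acid on the same phenyl ring would address.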